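The compounds below may be only part of what the source reports. "The series", "measured", "known", "first", "only" and "open" are said of these compounds alone.

Notes on the series in a functional assay on U-251 cells (Homo sapiens) for inhibition, read by MTT assay, with a stated time of 2 days; on this read-out higher numbers stand for lower toxicity in this test and lower numbers for higher toxicity in this test. Three compounds have been run so far. Compound 1 `Nc1ccccc1NC(=O)c1ccc(NCC(=O)Nc2cccc([N+](=O)[O-])c2)cc1` gives > 100000 nM in this assay, which is a limit of the assay and not a number. Compound 3 `Cc1ccc(NC(=O)CNc2ccc(C(=O)Nc3ccccc3N)cc2)cc1` likewise returns only the limit, > 100000 nM. Compound 2 `Nc1ccccc1NC(=O)CCCNCC(=O)Nc1cc(Cl)ccc1Cl` stands at the same limit, > 100000 nM. Among the measured compounds shown here, the single measured step between compounds that differ in one place, a step that the two limits leave unreadable from compound 1 to compound 3, cannot be read, both of its ends sitting at the limit. What the measured values show is simply (the limit of > 100000 nM in this assay, at which 3 of the 3 values shown sit).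

Compound 4 `Nc1ccccc1NC(=O)CCCNCC(=O)Nc1ccccc1Cl` remains to be measured. It differs from compound 2 in one place: hydrogen in place of chloro on an aromatic carbon. For the measured compounds named here, no measured step covers a change of this kind, and the only step available is unreadable, so neither a size nor a direction can be taken from the measured pairs; nothing beyond the usual scatter is expected. Compound 4 is therefore expected to sit at or near the limit, the expected step being a step that the limit leaves unreadable from compound 2 to compound 4. The estimate for compound 4 is 150000 nM, with an expected range from 60000 nM to 400000 nM.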

Compound 4, concentration lethal to 50% of the cells: > 100000 nM
Compound 4 ended at the assay's limit; the forecaster's own chance of this, stated with the estimate: 80%; the middle value lies beyond the limit too.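

Among the compounds shown here, compound 2 and compound 4 both return only a limit of the assay and not a number, so no step between them can be read: the limit of > 100000 nM in this assay, at which 4 of the 4 values shown sit. The compounds shown leave open whether any change to this series gives a readable value in this assay.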